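The source may hold more compounds than are shown below. What is called first, only, known or untested is meant among the compounds shown, and "the series" means these compounds.

Compound 2 `Cc1ccc(/C=C/C(=O)Oc2ccc(/C=C3\CCCC(CN(C)C)C3=O)cc2)cc1` gives the lowest number of the three measured in a functional assay on L1210 cells (Mus musculus) (a higher number here means a weaker inhibitor, a lower number a stronger inhibitor), with 2430 nM. Compound 1 `Cc1ccc(/C=C/C(=O)Oc2ccc(/C=C3\CCCCC3=O)cc2)cc1`, which lacks the (dimethylamino)methyl group, gives 202000 nM, and compound 3 `Cc1ccc(C(=O)Oc2ccc(/C=C3\CCCCC3=O)cc2)cc1`, which carries a 4-methylphenyl directly on the carbonyl carbon instead of the 2-(4-methylphenyl)ethenyl, gives 44800 nM. Among the measured compounds shown here, the one step measured, an 83-fold lower number from compound 1 to compound 2 (1.92 log units; beyond the scatter), concerns the saturated ring and not the ester side, so it does not touch the change considered here.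

Compound 4 `CN(C)CC1CCC/C(=C\c2ccc(OC(=O)c3ccc(Cl)cc3)cc2)C1=O` keeps the (dimethylamino)methyl of compound 2 and alters the ester: 4-chlorophenyl in place of 2-(4-methylphenyl)ethenyl on a carbonyl carbon. For the measured compounds named here, no measured step covers this change directly. The closest hint is the pair of compound 1 and compound 3, whose two values show a lower number when the 2-(4-methylphenyl)ethenyl is shortened to an aryl group on the carbonyl carbon; there is no comparison at all for methyl against chlorine on that ring. The account therefore expects compound 4 to give a number near or somewhat below that of compound 2, a step of a 2.4-fold lower number from compound 2 to compound 4 (0.39 log units; beyond the scatter) in this assay. The estimate for compound 4 is 1000 nM, with a range from 250 nM to 4000 nM.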

Compound 4, half-maximal inhibitory concentration: 5610 nM
Compound 4: middle estimate off by 5.6-fold (0.75 log units), on the low side, outside the stated range (above it).
By their numbers in this assay, from the lowest: compound 2; then compound 4; then compound 3; then compound 1.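

In this assay, a 2.3-fold higher number from compound 2 to compound 4 (0.36 log units; beyond the scatter) shows that, with the (dimethylamino)methyl group in place, 4-chlorophenyl on this carbonyl carbon does not give a lower number than 2-(4-methylphenyl)ethenyl. Without the (dimethylamino)methyl group, the shorter aryl ester had the lower number, with compound 1 at 202000 nM and compound 3 at 44800 nM, so the earlier direction does not carry over to this pair, although compound 3 bears 4-methylphenyl and not 4-chlorophenyl. Nothing available here explains this difference in direction.

The compounds shown do not separate the loss of the ethenyl link from the exchange of methyl for chlorine, as the two changes arrive together between the two compounds of this step, and a 4-methylphenyl ester carrying the (dimethylamino)methyl group would be needed to part them. Going by these compounds, how a 2-(4-chlorophenyl)ethenyl, a 4-methoxyphenyl or an unsubstituted phenyl would stand on this carbonyl carbon also remains open.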